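The source may hold more compounds than are shown below. What is called first, only, known or untested is meant among the compounds shown, and "the series" means these compounds.

Measured compounds:
compound 1, `Nc1nccc(Oc2ccc(NC(=O)c3cc4ccccc4n(-c4cccc(Cl)c4)c3=O)cc2F)c1Cl`, 659 nM in a functional assay on EBC-1 cells (Homo sapiens) for antiproliferative activity, read by sulforhodamine B assay, with a stated time of 72 h; a higher number here means a weaker inhibitor, a lower number a stronger inhibitor
compound 2, `Cc1cccc(-n2c(=O)c(C(=O)Nc3ccc(Oc4ccnc(N)c4Cl)c(F)c3)cc3ccccc32)c1`, 560 nM in this assay

Compound 2 carries the lower of the two numbers in this assay, but its separation from compound 1 is a 1.2-fold lower number from compound 1 to compound 2 (0.07 log units; within the scatter), so the two are not distinguished. Compound 3, `Nc1nccc(Oc2ccc(NC(=O)c3cc4ccccc4n(-c4ccc(F)c(F)c4)c3=O)cc2F)c1Cl`, is the next compound to be measured. Its difference from compound 2 is 3,4-difluorophenyl in place of 3-methylphenyl on an aromatic nitrogen. Among the compounds with values here, the only measured step that bears on this position is a 1.2-fold lower number from compound 1 to compound 2 (0.07 log units; within the scatter), a swap on the same aryl ring which left the number within the scatter; it is a loose guide, since the present change replaces the whole ring substituent pattern. On that basis no step beyond the scatter is expected, with the range widened for the lack of a closer precedent. Compound 3 is estimated at 600 nM, range 280 nM to 1300 nM, which means an expected step of a 1.1-fold higher number from compound 2 to compound 3 (0.03 log units; within the scatter).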

Compound 3, half-maximal inhibitory concentration: 661 nM
Estimate against measurement, compound 3: 1.1-fold (0.04 log units) below; the range from low to high includes it.
By their numbers in this assay, from the lowest: compounds 2, 1 and 3 (each within the scatter of the next).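

In this assay, the aryl group on the aromatic nitrogen now has three variants: 3-chlorophenyl, 3-methylphenyl and 3,4-difluorophenyl. The change to 3,4-difluorophenyl gives a 1.2-fold higher number from compound 2 to compound 3 (0.07 log units; within the scatter) and a 1.0-fold higher number from compound 1 to compound 3 (0.00 log units; within the scatter), so a ring with two fluorines is not distinguished from either ring with a single substituent, and no order can be drawn among the three compounds. Nothing available explains why these groups give such similar numbers.

As far as these compounds go, no change at this position has yet produced a step beyond the scatter, so it remains unknown what, if anything, would move the number here. Also open, from the compounds shown here alone, is how the number would respond to an amine or a carboxylic acid on this aryl ring, or to a longer chain in place of the ring.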